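Swapping the ring substituent of compound 2

This account rests on a few compounds, and the source may have more. Where it says the series, first, only, none or still open, it means among the compounds named here.

Measured in a functional assay on HOS-TE85 cells (Homo sapiens) for inhibition, read by CCK-8 assay, with a stated time of 72 h; a lower number here means a stronger inhibitor, a higher number a weaker inhibitor:
Compound 1 `COc1ccccc1N1C(=O)CSC1c1cccc(C(=O)NCCCCc2ccc(Cl)cc2)c1` gives 78.6 nM
Compound 2 `COc1ccccc1N1C(=O)CSC1c1cccc(C(=O)NCCCCn2cccn2)c1` gives 91.7 nM

On these numbers, compound 2 cannot be told apart from compound 1. Compound 3 `O=C(NCCCCn1cccn1)c1cccc(C2SCC(=O)N2c2cc(F)ccn2)c1` differs from compound 2 as follows: 4-fluoropyridin-2-yl in place of 2-methoxyphenyl on an amide-type nitrogen in a ring. In short, it has 4-fluoropyridin-2-yl in place of 2-methoxyphenyl on an amide-type nitrogen in a ring. For the measured compounds named here, the only measured step, a 1.2-fold higher number from compound 1 to compound 2 (0.07 log units; within the scatter), lies elsewhere, on a saturated chain carbon. Going by the values given here, no measured step touches this place, so the grounds are weak, and a moderate step to a higher number is expected from the value of compound 2 at 91.7 nM. The expected step is a 1.6-fold higher number from compound 2 to compound 3 (0.21 log units; within the scatter). For compound 3 the estimated value is 150 nM, within an expected range of 35 nM to 600 nM.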

Compound 3, half-maximal inhibitory concentration: 33.2 nM
For compound 3 the middle estimate is 4.5-fold (0.65 log units) above the measured one; the whole stated range lies above it.
By their numbers in this assay, from the lowest: compound 3; then compounds 1 and 2 (each within the scatter of the next).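

Putting 4-fluoropyridin-2-yl in place of 2-methoxyphenyl on the amide-type nitrogen in the ring gives a 2.8-fold lower number from compound 2 to compound 3 (0.44 log units; beyond the scatter) in this assay. So this position affects the read-out, whereas the change at the chain end, a 1.2-fold higher number from compound 1 to compound 2 (0.07 log units; within the scatter), did not separate compound 1 from compound 2. Nothing available explains the step.

The compounds shown leave open whether the pyridine nitrogen or the fluorine accounts for the step, which a 4-fluorophenyl or a plain pyridin-2-yl at this position could separate. They also leave open whether the step holds with 4-chlorophenyl at the chain end.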